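This account rests on a few compounds, and the source may have more. Where it says the series, first, only, none or still open, it means among the compounds named here.

Working notes on the series in a functional assay on HOS-TE85 cells (Homo sapiens) for inhibition, read by CCK-8 assay, with a stated time of 72 h; a higher number here means a weaker inhibitor, a lower number a stronger inhibitor.

Of the compounds shown here, three have numbers so far. Compound 1, `CC1SC(c2cccc(C(=O)NCCCCc3ccccc3)c2)N(c2ccc(C3CC3)cc2)C1=O`, gives 191 nM in this assay. Compound 2, `COc1ccccc1N1C(=O)CSC1c1cccc(C(=O)NCCCCc2ccc(Cl)cc2)c1`, gives 78.6 nM. Compound 3, `COc1cc(F)ccc1N1C(=O)CSC1c1cccc(C(=O)NCCCCc2ccccc2)c1`, gives 71.1 nM, the lowest of the three numbers; its gap to compound 2 is within the scatter, so no order between those two is claimed, while its gap to compound 1 is beyond the scatter.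

The next compound, compound 4, `O=C(NCCCCc1ccccc1)c1cccc(C2SCC(=O)N2c2nccs2)c1`, has not yet been measured in this assay. It differs from compound 3 at one place: 1,3-thiazol-2-yl in place of 4-fluoro-2-methoxyphenyl on an amide-type nitrogen in a ring. The group that enters sits on an amide-type nitrogen in a ring, next to the ring atom that bears a large group, two ring bonds from the ring sulfur. Within the data shown here, no pair among the measured compounds shows a change of this kind at that nitrogen, so the step from compound 3 cannot be read from a comparable measured step.

Given the spread among the three measured compounds, a modest move toward a higher number is expected for compound 4, with a 2.1-fold higher number from compound 3 to compound 4 (0.32 log units; beyond the scatter) in this assay, though a step no larger than the scatter is also plausible. Compound 4 is therefore estimated at 150 nM in this assay, within a range of 50 nM to 500 nM.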

Compound 4, half-maximal inhibitory concentration: > 1000 nM
Compound 4 gave a limit, no number; the forecaster's own chance of this, stated with the estimate: 5%; at least 6.6-fold (0.82 log units) between middle value and limit.
By their numbers in this assay, from the lowest: compounds 3 and 2 (each within the scatter of the next); then compound 1. At a limit, above all of these: compound 4.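

In this assay, among these compounds, the change to 1,3-thiazol-2-yl on the amide-type nitrogen in a ring gives an at least 14-fold higher number from compound 3 to compound 4 (1.14 log units; beyond the scatter), the first step at this position that can be read from a pair of compounds. Compound 4 gave only a limit, so this step sets a minimum size and not a measured size: the limit of > 1000 nM in this assay, at which 1 of the 4 values shown sits. Among the compounds shown here, the position is therefore not indifferent to which aromatic ring it carries, and the large step shows a sensitivity that the earlier compounds, with no pair differing at this nitrogen, could not show.

This single step does not separate ring size, the ring hetero atoms and the loss of the fluoro and methoxy groups from one another. Going by these compounds, whether pyridin-2-yl or unsubstituted phenyl on this nitrogen would give a measurable value in this assay remains open.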